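Swapping the ethyl on the amide-side ring for anilino

The source may report more compounds than this note shows. Statements on the series, on what has been measured and on what is new or still open speak of the compounds shown alone.

Two compounds share one core and differ only in the chain on the ring oxygen. Compound 1 `C=CCOc1ccc(C(=O)Nc2cccc(CC)n2)cc1` carries a vinyl-ended chain there, and compound 2 `CCCOc1ccc(C(=O)Nc2cccc(CC)n2)cc1` a propyl chain. In an in vitro assay on HEK-tsA201 cells for antagonist activity at Neuronal acetylcholine receptor; alpha4/beta2 (Homo sapiens), read by fluorescence and calcium flux (a higher number here means a weaker inhibitor, a lower number a stronger inhibitor), compound 1 gives 20500 nM, and compound 2 gives 37600 nM. Going by the values given here, the single measured step, a 1.8-fold higher number from compound 1 to compound 2 (0.26 log units; within the scatter), is small, so the two numbers are on the same footing; compound 2 stands at the higher of the two, with compound 1 close by.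

Compound 3 `CCCOc1ccc(C(=O)Nc2cccc(Nc3ccccc3)n2)cc1` keeps the propyl chain of compound 2 and changes the other ring: anilino in place of ethyl on an aromatic carbon. Among the compounds with values here, no measured step touches this part of the molecule, since the only step known concerns the chain on the oxygen. There is therefore no ground for predicting a shift in this assay in either direction, and the honest expectation is a number close to that of compound 2, with a wide margin for the unknown effect of a larger group.

On that basis the estimated step for compound 3 is a 1.3-fold lower number from compound 2 to compound 3 (0.10 log units; within the scatter). Compound 3 is thus expected to give about 30000 nM, within a range of 5000 nM to 150000 nM.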

Compound 3, half-maximal inhibitory concentration: > 100000 nM
Compound 3: no number, only a limit (the forecaster's own chance of this, stated with the estimate: 25%); middle value at least 3.3-fold (0.52 log units) from the limit.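

Compound 3 stands at a limit of the assay, not at a number: the limit of > 100000 nM in this assay, at which 1 of the 3 values shown sits. Even so, the position next to the ring nitrogen proves sensitive: anilino in place of ethyl on this aromatic carbon gives an at least 2.6-fold higher number from compound 2 to compound 3 (0.42 log units; beyond the scatter), so in this assay the change makes for a weaker inhibitor by an amount that can only be bounded from one side. The earlier step on the chain at the ring oxygen, a 1.8-fold higher number from compound 1 to compound 2 (0.26 log units; within the scatter), showed no such clear change, so this is the first sign that the compounds shown respond to a change in one part of the molecule.

Anilino brings in both a linking nitrogen and a carbon ring at once, so it remains open which of them matters: a benzyl group would keep the ring with carbon as the link, and a plain amine would keep the nitrogen without the ring. From the compounds shown here alone, it also remains open whether a group smaller than ethyl at this position, such as methyl, or a longer chain such as butyl, would give a stronger or a weaker inhibitor.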